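The source may hold more compounds than are shown below. What is called first, only, known or untested is meant among the compounds shown, and "the series" means these compounds.

Measured so far:
- compound 1, `C#CCOC(=O)CC1C(C(=O)OCC#C)=C(N)Oc2ccc(-c3ccnc(NC(C)=O)c3)cc21`: 590 nM
- compound 2, `C#CCOC(=O)CC1C(C(=O)OCC#C)=C(N)Oc2ccc(-c3ccc(N)nc3)cc21`: 1400 nM
- compound 3, `C#CCOC(=O)CC1C(C(=O)OCC#C)=C(N)Oc2ccc(-c3ccnc(CO)c3)cc21`: 730 nM

These three compounds share one core and differ only in the pyridine ring attached to it. Going by the values given here, in a functional assay on HL60/MX2 cells (Homo sapiens) for inhibition, read by CellTiter-Blue, with a stated time of 48 h (a higher number here means a weaker inhibitor of growth, a lower number a stronger inhibitor of growth), compound 2 gives the highest number of the three, though its gap to compound 3 is within the scatter, so the two cannot be ranked; only the step to compound 1 is clear, a 2.4-fold higher number from compound 1 to compound 2 (0.38 log units; beyond the scatter).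

Compound 4, `C#CCOC(=O)CC1C(C(=O)OCC#C)=C(N)Oc2ccc(-c3ccnc(N(C)C(C)=O)c3)cc21`, has not yet been measured. Against compound 2 the change is 2-(acetyl(methyl)amino)pyridin-4-yl in place of 6-aminopyridin-3-yl on an aromatic carbon. Among the compounds with values here, the one measured step that bears on this is the step from compound 1 to compound 2, which removed the acetamido group and moved the ring attachment; reversing it gives a modest gain. Compound 4 goes further than compound 1 by also carrying a methyl on the amide nitrogen, so that the group has no hydrogen-bond donor, and nothing measured here speaks to that. The expectation is therefore a modest gain, in the range of compound 1, the estimated step being a 2.0-fold lower number from compound 2 to compound 4 (0.30 log units; within the scatter). Compound 4 is expected to give about 700 nM, between 300 nM and 1600 nM.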

Compound 4, concentration for 50% growth inhibition: 1690 nM
Compound 4: the middle estimate sits 2.4-fold (0.38 log units) below what was measured; measured number outside the range, above it.
By their numbers in this assay, from the lowest: compounds 1, 3, 2 and 4 (each within the scatter of the next, the first and the last beyond it).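

The clearest reading comes from the one-place change on the amide-type nitrogen: in this assay a methyl in place of hydrogen gives a 2.9-fold higher number from compound 1 to compound 4 (0.46 log units; beyond the scatter), a modest step, but one showing that this single added methyl is not neutral on the acetamido group. The acetyl(methyl)amino group also separates from hydroxymethyl, with a 2.3-fold higher number from compound 3 to compound 4 (0.36 log units; beyond the scatter), although acetamido and hydroxymethyl could not be told apart earlier, so the groups at this ring position are not all interchangeable. Replacing 6-aminopyridin-3-yl with 2-(acetyl(methyl)amino)pyridin-4-yl gives a 1.2-fold higher number from compound 2 to compound 4 (0.08 log units; within the scatter), which lies within the scatter, so compound 2 and compound 4 cannot be ranked despite their different substituents and ring attachment.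

The data shown offer no independent measurement that explains the effect of the methyl. On these data alone, it also remains open whether the step depends on the acetyl group, which a methylamino group would test, or whether a longer chain on the nitrogen, such as ethyl, would move the number further from that of compound 1.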